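The source may hold more compounds than are shown below. What is called first, only, known or untested is meant among the compounds shown, and "the series" means these compounds.

Measured compounds:
compound 1, `COc1ccc(-c2cc(/N=C3\SCC(=O)N3c3cccc(OC)c3)cs2)cc1`, 2700 nM
compound 2, `CN(C)c1ccc(/C=C2\S/C(=N\c3nc(-c4ccc(Cl)cc4)cs3)NC2=O)cc1`, 200 nM

In a functional assay on HCT-116 cells (Homo sapiens) for cytotoxicity, read by MTT assay, with a stated time of 72 h (on this read-out higher numbers stand for weaker inhibition and lower numbers for stronger inhibition), compound 2 holds the lower of the two numbers shown, with compound 1 standing well apart and beyond the scatter. Among the compounds with values here, no step between measured compounds is available for the change now considered. Compound 3, `COc1ccc(/C=C2\S/C(=N\c3nc(-c4ccc(Cl)cc4)cs3)NC2=O)cc1`, carries methoxy in place of dimethylamino on an aromatic carbon, methoxy in place of dimethylamino on an aromatic carbon. With nothing measured on this exchange, only a modest step is expected, leaning towards a higher number, since compound 2 gives 200 nM and sets the reference. Compound 3 is estimated at 500 nM, within 150 nM to 2500 nM, an expected step of a 2.5-fold higher number from compound 2 to compound 3 (0.40 log units; beyond the scatter).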

Compound 3, half-maximal inhibitory concentration: 400 nM
Compound 3: middle estimate off by 1.3-fold (0.10 log units), on the high side; the range from low to high includes it.
By their numbers in this assay, from the lowest: compounds 2 and 3 (each within the scatter of the next); then compound 1.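

In this assay, methoxy in place of dimethylamino on an aromatic carbon gives a 2.0-fold higher number from compound 2 to compound 3 (0.30 log units; within the scatter), so the two groups read alike at this position. The dimethylamino group is therefore not needed for a value in this range within this pair. No measured evidence bears on this result.

Still open, as far as these compounds go, is whether a hydroxyl, a carboxylic acid or a morpholine at the same carbon would stay within this range. The pair also leaves open whether this exchange would read the same on the core of compound 1.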